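Amino for Cyclopropyl at the Carbonyl: Compound 4 Expected

This account rests on a few compounds, and the source may have more. Where it says the series, first, only, none or still open, it means among the compounds named here.

Measured compounds:
compound 1 `CC1=C(C(=O)C2CC2)C(c2ccco2)NC(=O)N1`: 2%
compound 2 `CC1=C(C(=O)C2CC2)C(c2ccoc2)NC(=O)N1`: 1%
compound 3 `CC1=C(C(=O)C2CC2)C(c2ccsc2)NC(=O)N1`: 2%

In an assay on membranes from CHO cells for displacement of a labelled ligand from adenosine receptor A1 (Homo sapiens), read by scintillation counting, with a stated time of 60 min, tested at 1 uM (on this read-out lower numbers stand for less inhibition and higher numbers for more inhibition at the one concentration tested (going by the name of the read-out)), compound 3 gives 2%, the same figure at the digits shown as compound 1 and within the usual scatter of compound 2. The two steps that lead to it, no change at the digits printed from compound 1 to compound 3 (within the scatter) and a number 1 percentage points higher from compound 2 to compound 3 (within the scatter), both lie within the scatter, as does a number 1 percentage points lower from compound 1 to compound 2 (within the scatter). All three measured compounds share one core and differ only in the five-membered aromatic ring on the saturated ring carbon; none of them changes the group on the carbonyl carbon.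

Compound 4 `CC1=C(C(N)=O)C(c2ccsc2)NC(=O)N1` differs from compound 3 at exactly that carbonyl: amino in place of cyclopropyl on a carbonyl carbon. Within the data shown here, no measured step touches this part of the molecule, so there is no step in the data that bears on the change. What the data do show is that the whole series sits at low inhibition in this assay whatever is varied, with every step within the scatter. On that basis compound 4 is expected to stay at the same low level, and the step of no change at the digits printed from compound 3 to compound 4 (within the scatter) is estimated to be none beyond the scatter. For compound 4 the estimate in this assay is 2%, with a range from -8% to 12%.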

Compound 4, a percentage reported as inhibition, at one concentration (the size of the read-out at that concentration, not a potency): 2%
Compound 4: middle estimate and measured number agree at the digits printed, and the stated range covers the measured number.
By their numbers in this assay, from the lowest: compounds 2, 1, 3 and 4 (each within the scatter of the next).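

Among these compounds, with this assay as the read-out, compound 4 gives the first reading for a change at the carbonyl carbon rather than on the five-membered aromatic ring, and the step is no change at the digits printed from compound 3 to compound 4 (within the scatter). Amino in place of cyclopropyl removes a three-membered non-aromatic ring of carbon only and brings in a hydrogen-bond donor, yet this exchange of cyclopropylcarbonyl for carbamoyl leaves the number within the scatter, so the low level of inhibition seen with the thiophen-3-yl compounds does not depend on keeping cyclopropyl at this position. Nothing available explains why the read-out stays level across this change.

The compounds shown leave open whether a larger group on the carbonyl carbon, such as a phenyl ring, an ethoxy group, a dimethylamino group or a longer alkyl chain, would move the number beyond the scatter. They also leave open whether amino in place of cyclopropyl would give the same result with furan-2-yl or furan-3-yl on the saturated ring carbon, since this change is seen here only with thiophen-3-yl.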